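Swapping dimethylphenyl for aminophenyl on the shared core

The source may hold more compounds than are shown below. What is called first, only, known or untested is meant among the compounds shown, and "the series" means these compounds.

Values in a functional assay on MCF7 cells (Homo sapiens) for antiproliferative activity, read by MTT assay, with a stated time of 72 h; a higher number here means a weaker inhibitor, a lower number a stronger inhibitor:
- Compound 1 `COc1cc(-n2cnc3ccc(-c4cccc(C)c4)cc32)cc(OC)c1OC`: 360 nM
- Compound 2 `COc1cc(-n2cnc3ccc(-c4cccc(C)c4C)cc32)cc(OC)c1OC`: 2150 nM

Of these two compounds, compound 2 has the higher number and so is the weaker inhibitor, with compound 1 as its nearest neighbour. Compound 3 `COc1cc(-n2cnc3ccc(-c4cccc(N)c4)cc32)cc(OC)c1OC` has 3-aminophenyl in place of 2,3-dimethylphenyl on an aromatic carbon. Within the data shown here, only one measured step bears on this change: a 6.0-fold higher number from compound 1 to compound 2 (0.78 log units; beyond the scatter), which came with methyl in place of hydrogen on an aromatic carbon. Compound 3 does not carry the added methyl of compound 2, so a return towards the value of compound 1, 360 nM, is expected. Among the measured compounds shown here, no measurement yet shows how an amino group behaves here, so the range stays wide. The expected change is a 4.3-fold lower number from compound 2 to compound 3 (0.63 log units; beyond the scatter), a move to a lower number in this assay. For compound 3 the estimated value is 500 nM, with an expected range from 130 nM to 1900 nM.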

Compound 3, half-maximal inhibitory concentration: 180 nM
Estimate against measurement, compound 3: 2.8-fold (0.44 log units) above; the range from low to high includes it.
By their numbers in this assay, from the lowest: compounds 3 and 1 (each within the scatter of the next); then compound 2.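

In this assay, 3-aminophenyl in place of 2,3-dimethylphenyl gives a 12-fold lower number from compound 2 to compound 3 (1.08 log units; beyond the scatter) and is the largest step seen so far, though it changes two things at once: one methyl is lost and the other becomes an amino group. Amino in place of methyl alone gives a 2.0-fold lower number from compound 1 to compound 3 (0.30 log units; within the scatter), so this assay does not separate those two groups, and the large step tracks the loss of the extra methyl present only in compound 2. Nothing available here explains these numbers.

A hydroxyl group or a carboxylic acid in place of the amino group remains an open case. Also open, as far as these compounds go, is whether adding the extra methyl to the ring of compound 3 would raise its number, as the same addition did for compound 1.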